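The source may report more compounds than this note shows. Statements on the series, on what has been measured and on what is new or still open speak of the compounds shown alone.

Three compounds have been measured so far in a functional assay on MCF7 cells (Homo sapiens) for cytotoxicity, read by MTT assay, with a stated time of 48 h; a higher number here means a weaker inhibitor, a lower number a stronger inhibitor:

Compound 2 `CCCCCCCCNC(=O)[C@@H](NC(=O)c1ccccc1)[C@@H](C)O`: 111000 nM
Compound 3 `CCCCCCCCNC(=O)[C@@H](NC(=O)c1ccco1)[C@@H](C)O`: 91800 nM
Compound 1 `CCCCCCCCCCCCCCNC(=O)[C@@H](N)[C@@H](C)O`: 10700 nM

Compound 2 gives the highest number of the three. Its nearest neighbour is compound 3, which differs only by a furan-2-yl in place of phenyl on the carbonyl carbon, and the step of a 1.2-fold lower number from compound 2 to compound 3 (0.08 log units; within the scatter) is within the scatter. Compound 1 differs from compound 2 in more than one place and shows a clearly lower number.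

Compound 4 `CCCCCCCCNC(=O)[C@@H](NC(=O)/C=C/c1ccccc1)[C@@H](C)O` is the next compound. It differs from compound 2 as follows: 2-phenylethenyl in place of phenyl on a carbonyl carbon. Going by the values given here, the only measured step at this position, from compound 2 to compound 3, stayed within the scatter, so the step of a 1.4-fold lower number from compound 2 to compound 4 (0.14 log units; within the scatter) is expected to be small as well. Compound 4 is therefore estimated at 80000 nM, with a range from 30000 nM to 200000 nM.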

Compound 4, half-maximal inhibitory concentration: 35100 nM
Compound 4: middle estimate off by 2.3-fold (0.36 log units), on the high side; the range from low to high includes it.
By their numbers in this assay, from the lowest: compound 1; then compound 4; then compounds 3 and 2 (each within the scatter of the next).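

In this assay this place on the carbonyl carbon can move the number beyond the scatter: 2-phenylethenyl in place of phenyl gives a 3.2-fold lower number from compound 2 to compound 4 (0.50 log units; beyond the scatter) and 2-phenylethenyl in place of furan-2-yl gives a 2.6-fold lower number from compound 3 to compound 4 (0.42 log units; beyond the scatter). The earlier swap of one ring for another did not do this, whereas 2-phenylethenyl keeps the phenyl ring and adds a double bond outside it. No measurement here explains the larger step.

A saturated 2-phenylethyl group would show whether the double bond matters. An amine or a carboxylic acid on the phenyl ring remains an open case.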